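The compounds below may be only part of what the source reports. "The series", "measured", "known", "first", "only" and "open" are said of these compounds alone.

Measured in an ADME assay on L929 cells (Mus musculus) for cytotoxicity, read by resazurin assay, with a stated time of 96 h; on this read-out lower numbers stand for higher toxicity in this test and higher numbers for lower toxicity in this test:
- compound 1 `NC(=S)N/N=C(/COc1ccc(Br)cc1)c1ccccc1`: < 27500 nM (a limit)
- compound 2 `NC(=S)N/N=C(/COc1ccc(Br)cc1)c1ccc(F)cc1`: < 26200 nM (a limit)
- compound 3 `CC(C)(C)c1ccc(OC/C(=N\NC(N)=S)c2ccc(Br)cc2)cc1`: 23800 nM

Among the compounds with values here, compound 3 holds the only number, as the other two entries are limits. Compound 4 `NC(=S)N/N=C(\COc1ccc(Cl)cc1)c1ccc(Br)cc1` carries chloro in place of tert-butyl on an aromatic carbon. Within the data shown here, the only measured step, a step that the two limits leave unreadable from compound 1 to compound 2, is a different exchange and offers no size to carry over. The expectation leans instead on compound 2, which has bromo on the ring that changes, and its < 26200 nM is a limit. The expected step is a 1.4-fold lower number from compound 3 to compound 4 (0.15 log units; within the scatter), tending toward lower numbers in this assay. The estimate for compound 4 is 17000 nM, with an expected range from 7000 nM to 32000 nM.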

Compound 4, half-maximal cytotoxic concentration: < 25100 nM
Compound 4: no number, only a limit; the forecaster's own chance of this, stated with the estimate: 55%; the middle value is on the limit's open side.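

Compound 4 gives < 25100 nM, a limit and not a number. The step from compound 3 to compound 4 therefore cannot be read. Still open, on these data alone, is how far chloro in place of tert-butyl shifts the read-out in this assay.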